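Selenium heteroaryl series: cytotoxicity on fibroblasts, compound 4

This account rests on a few compounds, and the source may have more. Where it says the series, first, only, none or still open, it means among the compounds named here.

Measured compounds:
Compound 1 `COc1ccc2[nH]c(-c3ccc[se]3)cc(=O)c2c1O`: 100000 nM
Compound 2 `COc1ccc2[nH]c(-c3ccc(C)[se]3)cc(=O)c2c1O`: > 50000 nM
Compound 3 `COc1ccc2[nH]c(-c3ccc(C)[se]3)cc(=O)c2c1`: > 10000 nM

In an ADME assay on Detroit 551 cells (Homo sapiens) for cytotoxicity, read by MTT assay, with a stated time of 48 h (a lower number here means a stronger inhibitor, a higher number a weaker inhibitor), compound 1 gives 100000 nM. For compound 2 the figure > 50000 nM is a limit of the assay, not a number. For compound 3 the figure > 10000 nM is likewise a limit. Compound 3 therefore stands among the three at a limit only; of the other two values, one is also a limit and one is a number.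

The step from compound 1 to compound 2, methyl in place of hydrogen on an aromatic carbon, reads a step that the limit leaves unreadable from compound 1 to compound 2. The step from compound 2 to compound 3, hydrogen in place of hydroxy on an aromatic carbon, reads a step that the two limits leave unreadable from compound 2 to compound 3. Both are left unreadable, because of the limit of > 50000 nM in this assay, at which 1 of the 3 values shown sits, and (the limit of > 10000 nM in this assay, at which 1 of the 3 values shown sits).

Compound 4 `COc1ccc2[nH]c(-c3cc[se]c3)cc(=O)c2c1` differs from compound 3 by a group of 5 heavy atoms (4 carbon, 1 selenium; one five-membered aromatic ring with 1 hetero atom) in place of a group of 6 heavy atoms (5 carbon, 1 selenium; one five-membered aromatic ring with 1 hetero atom), on an aromatic carbon. Within the data shown here, no measured step concerns this change, and the steps that exist give no size. No step beyond the scatter is therefore expected in this assay; compound 4 is expected to remain near the limit of compound 3, with a step that the limit leaves unreadable from compound 3 to compound 4 as the estimated step. The estimate for compound 4 is 50000 nM, in the range 10000 nM to 150000 nM.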

Compound 4, half-maximal inhibitory concentration: > 10000 nM
Compound 4 ended at the assay's limit; the forecaster's own chance of this, stated with the estimate: 70%; the middle value lies beyond the limit too.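

No step can be read from compound 3 to compound 4, because both values are limits and not numbers: the limit of > 10000 nM in this assay, at which 2 of the 4 values shown sit.

The compounds shown leave open whether the group of 5 heavy atoms and the group of 6 heavy atoms differ at all in this assay, and what number either compound would reach there.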